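Chloro on the shared core: note on compound 4

A few compounds are considered here, and "the series" means these few. Any claim that something is new, unique, unknown or untested is made for them only; others in the source may bear on it.

Measured compounds:
- compound 1, `Cc1cn(Cc2ccc(O)c(C(C)C)c2)c2ccc(OCC(=O)O)cc12`: 0.38 nM
- compound 2, `Cc1cc(OCC(=O)O)cc2ccn(Cc3ccc(O)c(C(C)C)c3)c12`: 0.26 nM
- compound 3, `Cc1cc(OCC(=O)O)cc2cc(C)n(Cc3ccc(O)c(C(C)C)c3)c12`: 0.14 nM

In an assay on HeLa cells for displacement of a labelled ligand from thyroid hormone receptor beta (Homo sapiens) (on this read-out higher numbers stand for weaker inhibition and lower numbers for stronger inhibition), compound 1 gives 0.38 nM, the highest of the three numbers; the gap to compound 2 lies within the scatter and only the gap to compound 3 lies beyond it. Within the data shown here, the one step between compounds that differ in a single place is a 1.9-fold lower number from compound 2 to compound 3 (0.27 log units; within the scatter), a methyl entering on an aromatic carbon, which stays within the scatter.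

Compound 4, `Cc1cn(Cc2ccc(O)c(C(C)C)c2)c2c(Cl)cc(OCC(=O)O)cc12`, is not yet measured. It differs from compound 1 by chloro in place of hydrogen on an aromatic carbon; the chloro enters on an aromatic carbon of a six-membered aromatic ring of carbon only, part of a fused system of two rings, ortho to a fused ring, meta to a carboxymethoxy group and meta to a fused ring. Among the measured compounds shown here, no measured step puts a chloro on the core, so the only guide is that a small substituent on an aromatic carbon, in the step from compound 2 to compound 3, moved the number within the scatter. For compound 4 the expected step is therefore a 1.3-fold lower number from compound 1 to compound 4 (0.10 log units; within the scatter), no change beyond the scatter in this assay. Compound 4 is expected to give 0.3 nM, with a range of 0.12 nM to 0.8 nM.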

Compound 4, inhibition constant: 0.09 nM
Estimate against measurement, compound 4: 3.3-fold (0.52 log units) above, outside the stated range (below it).
By their numbers in this assay, from the lowest: compounds 4, 3, 2 and 1 (each within the scatter of the next, the first and the last beyond it).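

In this assay, among these compounds, chloro on this aromatic carbon, ortho to a fused ring and meta to a carboxymethoxy group, gives the first single-place step that lies beyond the scatter: a 4.2-fold lower number from compound 1 to compound 4 (0.63 log units; beyond the scatter). Among the compounds shown here, the only earlier single-place step, a 1.9-fold lower number from compound 2 to compound 3 (0.27 log units; within the scatter), put a methyl on an aromatic carbon and stayed within the scatter, so a change on an aromatic carbon can now be seen to move the number measurably, though the two steps differ in both group and place and do not isolate either one. Nothing at hand gives a reason for the step from hydrogen to chloro.

The compounds shown carry only hydrogen or chloro at this carbon, so it remains open whether a fluoro, a bromo, a methyl, a methoxy or an amine there would give a step of similar size. As far as these compounds go, it also remains open whether chloro would give a step of this size on other aromatic carbons of the shared core.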